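This account rests on a few compounds, and the source may have more. Where it says the series, first, only, none or still open, it means among the compounds named here.

The compounds here share a sugar-bearing core and differ in the groups hanging from it. Compound 1 `OC[C@H]1O[C@@H](n2cnc3c(NC4CCCC4)nc(NCCOCc4ccccc4)nc32)[C@H](O)[C@@H]1O` has been tested in an ADME assay on L6 cells (Rattus norvegicus) for cytotoxicity (a higher number here means a weaker inhibitor, a lower number a stronger inhibitor), and gives 78800 nM, a weak effect on the cells. Compound 2 `COc1nc(Nc2ccccc2)c2ncn([C@@H]3O[C@H](CO)[C@@H](O)[C@H]3O)c2n1` was also part of the series, but in this assay the entry for compound 2 reads "not determined" (no result reported), so no result was reported for it. Compound 3 `OC[C@H]1O[C@@H](n2cnc3c(NCc4cccc(I)c4)nc(NCCOCc4ccccc4)nc32)[C@H](O)[C@@H]1O` carries a 3-iodobenzyl group on a nitrogen on an aromatic ring whose other neighbour is an aromatic carbon; for compound 3 too, the entry in this assay for compound 3 reads "not determined" (no result reported), so it stands without a value, and compound 2 is the one further entry in the same position.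

Compound 4 `OC[C@H]1O[C@@H](n2cnc3c(Nc4ccccc4)nc(NCCOCc4ccccc4)nc32)[C@H](O)[C@@H]1O` is the next compound, not yet measured. It differs from compound 3 in a single place: phenyl in place of 3-iodobenzyl on a nitrogen on an aromatic ring. Within the data shown here, no measured pair shows what such a swap does in this assay, so the size and direction of the step cannot be read from the data; nothing beyond the usual scatter is expected either way, and the only anchor is the weak value of compound 1, which is 78800 nM. On that basis compound 4 is expected to give about 80000 nM in this assay, with a plausible range from 30000 nM to 250000 nM.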

Compound 4, half-maximal inhibitory concentration: 53800 nM
Compound 4: middle estimate off by 1.5-fold (0.17 log units), on the high side; the range from low to high includes it.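

In this assay, among these compounds, there is now a first pair that differs in one place, and phenyl in place of cyclopentyl on a nitrogen on an aromatic ring gives a 1.5-fold lower number from compound 1 to compound 4 (0.17 log units; within the scatter). This means that, in this one pair, the saturated carbon ring and the aromatic carbon ring cannot be told apart: both compounds remain in the same weak range of effect on the cells, and the exchange produces no change larger than repeated measurements would. Nothing available explains why these two groups read alike.

Going by these compounds, every step involving compound 2 or compound 3 cannot be read, as neither compound has a result, so the effect of 3-iodobenzyl at this position remains unknown, including its comparison with phenyl in compound 4. Also open, on these data alone, is whether any group on this nitrogen can move the number beyond the scatter, for example a phenyl ring carrying a carboxylic acid or an amine, or a longer chain in place of the ring.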